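Two Limits and a Methoxy Swap

The source may report more compounds than this note shows. Statements on the series, on what has been measured and on what is new or still open speak of the compounds shown alone.

Compound 1 `CCN1CCN(c2ccc(S(=O)(=O)Oc3ccccc3OC)cc2)C1=O`: > 100000 nM
Compound 2 `CCCN1CCN(c2ccc(S(=O)(=O)Oc3ccccc3CC)cc2)C1=O`: > 50000 nM

In a functional assay on M21 cells (Homo sapiens) for antiproliferative activity, read by sulforhodamine B assay, with a stated time of 48 h (on this read-out lower numbers stand for stronger inhibition and higher numbers for weaker inhibition), compound 2 stands at > 50000 nM, which is a limit of the assay and not a number. Compound 1 also gives only a limit, > 100000 nM. Among the compounds with values here, neither compound therefore has a measured potency, and no measured step is available as a guide.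

Compound 3 `CCCN1CCN(c2ccc(S(=O)(=O)Oc3ccccc3OC)cc2)C1=O` differs from compound 2 by having methoxy in place of ethyl on an aromatic carbon, ortho to a large group (methoxy in place of ethyl on an aromatic carbon). In other words, 2-ethylphenyl becomes 2-methoxyphenyl.

Compound 2 offers only the limit > 50000 nM, so no step beyond the usual scatter is expected in this assay, in either direction. The expected change is a step that the limit leaves unreadable from compound 2 to compound 3. Compound 3 is estimated at 80000 nM, with an expected range of 20000 nM to 200000 nM.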

Compound 3, half-maximal inhibitory concentration: > 100000 nM
Compound 3: no number, only a limit; the forecaster's own chance of this, stated with the estimate: 75%; at least 1.2-fold (0.09 log units) between middle value and limit.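

In this assay compound 3 gives > 100000 nM, which is a limit of the assay and not a number. The steps to it from compound 1 and from compound 2 therefore cannot be read. The compounds shown leave open how potent any of the three really is, and whether methoxy in place of ethyl changes that potency at all.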